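The source may report more compounds than this note shows. Statements on the series, on what has been measured and on what is new or still open speak of the compounds shown alone.

Measured compounds and values:
Compound 1 `CCOc1ccccc1-n1nncc1CN1C(=O)C2(C(C#N)=C(N)Oc3c(N)cc4nc5ccccc5nc4c32)c2ccccc21`: 30500 nM in a functional assay on HepG2 cells (Homo sapiens) for antiproliferative activity, read by MTT assay, with a stated time of 48 h; on this read-out lower numbers stand for stronger inhibition and higher numbers for weaker inhibition
Compound 2 `Cc1ccc(-n2nncc2CN2C(=O)C3(C(C#N)=C(N)Oc4c(N)cc5nc6ccccc6nc5c43)c3ccccc32)cc1C`: > 50000 nM in this assay, a limit of the assay rather than a number

Both compounds share one core and differ only in the aromatic group carried on the ring nitrogen. Compound 2 stands at the upper limit of this assay: there is only a bound for it, not a measured number. Compound 3 `Cc1cc(C)c(-n2nncc2CN2C(=O)C3(C(C#N)=C(N)Oc4c(N)cc5nc6ccccc6nc5c43)c3ccccc32)c(C)c1` has not been measured; it changes compound 2 by 2,4,6-trimethylphenyl in place of 3,4-dimethylphenyl on an aromatic nitrogen. Going by the values given here, only one measured step touches this position: an at least 1.6-fold higher number from compound 1 to compound 2 (0.21 log units; that floor lies within the scatter), and it ends at the limit (the limit of > 50000 nM in this assay, at which 1 of the 2 values shown sits). That step, already uncertain in size, points if anywhere toward weaker inhibition, and the move to 2,4,6-trimethylphenyl does not repeat any change whose effect has been measured. The expected step is a step that the limit leaves unreadable from compound 2 to compound 3, that is, no clear shift beyond the scatter from a value that is itself a limit. Compound 3 is therefore estimated at 70000 nM, within 35000 nM to 150000 nM, and most likely the assay will again report only its limit.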

Compound 3, half-maximal inhibitory concentration: 48100 nM
For compound 3 the middle estimate is 1.5-fold (0.16 log units) above the measured one, and the stated range covers the measured number.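

In this assay compound 3 gives 48100 nM, so a phenyl ring carrying only methyl groups on this aromatic nitrogen now has a real number rather than a bound. Set against 2-ethoxyphenyl, the change shows a 1.6-fold higher number from compound 1 to compound 3 (0.20 log units; within the scatter), so 2,4,6-trimethylphenyl and 2-ethoxyphenyl cannot be told apart in this assay, and swapping one for the other brings no clear gain or loss of inhibition. The change from 3,4-dimethylphenyl reads as an at least 1.0-fold lower number from compound 2 to compound 3 (0.01 log units; that floor lies within the scatter), and its true size stays unknown: the limit of > 50000 nM in this assay, at which 1 of the 3 values shown sits.

Every group shown at this position is a phenyl ring bearing methyl or ethoxy groups, so it remains open whether a ring bearing an amine or a carboxylic acid, or a longer chain in place of the ring, would move the number beyond the scatter. The compounds shown also leave open whether changes elsewhere on the shared core would matter more than changes at this position.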